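Pyridyl oxadiazoline indole cinnamoyl series: chlorophenyl isomer

A few compounds are considered here, and "the series" means these few. Any claim that something is new, unique, unknown or untested is made for them only; others in the source may bear on it.

Measured so far in an ADME assay on PANC-1 cells (Homo sapiens) for cytotoxicity, read by MTT assay, with a stated time of 48 h; on this read-out higher numbers stand for weaker inhibition of growth and lower numbers for stronger inhibition of growth:
Compound 1 `O=C(/C=C\c1cccc(O)c1)N1N=C(c2ccncc2)OC1c1c[nH]c2ccccc12` gives > 30 ug/mL, a limit of the assay.
Compound 2 `O=C(/C=C\c1ccc(F)cc1)N1N=C(c2ccncc2)OC1c1c[nH]c2ccccc12` gives > 30 ug/mL, a limit of the assay.
Compound 3 `O=C(/C=C\c1cccc(Cl)c1)N1N=C(c2ccncc2)OC1c1c[nH]c2ccccc12` gives > 30 ug/mL, a limit of the assay.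

Compound 3 stands where every measured member of the series stands: at the limit of this assay, with no number beneath it, as the limit of > 30 ug/mL in this assay, at which 3 of the 3 values shown sit, records. The steps among the measured compounds, a step that the two limits leave unreadable from compound 1 to compound 2, a step that the two limits leave unreadable from compound 1 to compound 3 and a step that the two limits leave unreadable from compound 2 to compound 3, are all unreadable, since both ends of each sit at that limit; none of them gives a direction or a size.

Compound 4 `O=C(/C=C\c1ccc(Cl)cc1)N1N=C(c2ccncc2)OC1c1c[nH]c2ccccc12` is not yet measured. It differs from compound 3 as 4-chlorophenyl in place of 3-chlorophenyl on a double-bonded chain carbon bound to a double-bonded chain carbon. The measured steps cannot say how large a step to expect in this assay for compound 4, nor in which direction. With nothing in the series falling below the limit, the expectation for compound 4 is again no reading beneath the limit, an estimated 50 ug/mL within 20 ug/mL to 200 ug/mL, which means an expected step that the limit leaves unreadable from compound 3 to compound 4 that is not beyond the scatter.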

Compound 4, concentration for 50% growth inhibition: > 30 ug/mL
Compound 4 gave a limit, no number; the forecaster's own chance of this, stated with the estimate: 80%; the middle value does not contradict the limit.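

In this assay compound 4 gives > 30 ug/mL, a limit and not a number. Its steps to compound 1, compound 2 and compound 3 cannot be read, as all four compounds sit at the same limit: the limit of > 30 ug/mL in this assay, at which 4 of the 4 values shown sit.

The compounds shown leave open whether any group on the shared core gives a readable value, and how 3-chlorophenyl and 4-chlorophenyl compare.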